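This account rests on a few compounds, and the source may have more. Where it says the series, first, only, none or still open, it means among the compounds named here.

Measured so far in an ADME assay on Vero cells (Chlorocebus sabaeus) for cytotoxicity, read by WST assay, tested at 100 ug/mL; a higher number here means a weaker effect of the compound at the concentration tested, a lower number a stronger effect:

- compound 1, `COC(=O)[C@@H]1COC(/C=C/c2ccc(F)cc2)=N1`: 18.6%
- compound 2, `COC(=O)c1coc(/C=C/c2ccc(F)cc2)n1`: 99%

In this assay compound 1 gives 18.6% and compound 2 gives 99%. Compound 2 therefore stands highest of the two numbers; its nearest neighbour, compound 1, lies far lower, and that gap is well beyond the usual scatter. For the measured compounds named here, the two compounds differ in more than one place, so no single step is drawn between them; the values are simply set side by side.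

The next compound in the series is compound 3, `COC(=O)c1coc(/C=C/c2ccc(C)cc2)n1`. It is compound 2 with one change:

methyl in place of fluoro on an aromatic carbon

Compound 2 already sits close to the top of what this assay can report, leaving little room for a higher number, and a methyl in place of fluoro is a small change on the six-membered aromatic ring of carbon only. The step from compound 2 to compound 3 is therefore expected to be a number 5 percentage points lower from compound 2 to compound 3 (within the scatter), that is, none beyond the scatter. Compound 3 is accordingly estimated at 94%, with an expected range from 78% to 100%.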

Compound 3, a percentage reported as activity, at one concentration (the size of the read-out at that concentration, not a potency): 100%
Estimate against measurement, compound 3: 6 percentage points below; measured number inside the range.
By their numbers in this assay, from the lowest: compound 1; then compounds 2 and 3 (each within the scatter of the next).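

In this assay, methyl in place of fluoro on an aromatic carbon of the six-membered aromatic ring of carbon only, para to a large group, gives a number 1 percentage points higher from compound 2 to compound 3 (within the scatter); at this position the read-out does not separate the two groups. This is a limited finding: compound 3 gives 100%, the top of a percentage scale, and a weaker effect than that could not register in this assay, leaving the pair with no room to show a further rise. No measurement is available that bears on this result.

From the compounds shown here alone, whether any group at this position can bring the number down beyond the scatter remains open, for example an amine, a carboxylic acid, a nitrile or a longer chain in place of methyl or fluoro. Also open, going by these compounds, is whether methyl in place of fluoro would stay as quiet on the core of compound 1, which gives 18.6% and therefore has room to move in either direction in this assay.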